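Ring-nitrogen substitution in the thioether amide series

The source may report more compounds than this note shows. Statements on the series, on what has been measured and on what is new or still open speak of the compounds shown alone.

Measured compounds:
compound 1 `N#Cc1c(-c2ccc(O)cc2)nc(SCC(=O)Nn2c(COc3ccc(Cl)cc3Cl)nc3ccccc3c2=O)[nH]c1=O` — 63.6%
compound 2 `Cn1c(SCC(=O)Nn2c(COc3ccc(Cl)cc3Cl)nc3ccccc3c2=O)nc(-c2ccc(O)cc2)c(C#N)c1=O` — 80%

In a functional assay on the whole organism (strain albino) for inhibition, with Rattus norvegicus as the target, read by paw edema, with a stated time of 1 h, at a dose of 100 mg/kg by the oral route (a higher number here means more inhibition at the dose given (going by the name of the read-out), a lower number less inhibition), compound 1 gives 63.6% and compound 2 gives 80%. Within the data shown here, compound 2 stands highest of the two numbers; the only other compound, compound 1, lies below it by a step beyond the scatter, a number 16.4 percentage points higher from compound 1 to compound 2 (beyond the scatter), which came with methyl in place of hydrogen on an aromatic nitrogen.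

Compound 3 `N#Cc1c(-c2ccc(O)cc2)nc(SCC(=O)Nn2c(COc3ccc(Cl)cc3Cl)nc3ccccc3c2=O)n(Cc2ccccc2)c1=O` has not yet been measured in this assay. It differs from compound 2 by phenyl in place of hydrogen on a saturated chain carbon bound to an aromatic nitrogen; cut one bond further out, the change reads methyl to benzyl. Among the measured compounds shown here, the only measured step touches the same aromatic nitrogen, but it swaps hydrogen for methyl, not methyl for benzyl, so it bears only loosely on the present change. That step was modest and upward; nothing here shows how a larger group on that nitrogen behaves. A step no larger than the scatter is therefore expected, a number 5 percentage points lower from compound 2 to compound 3 (within the scatter), with a wide range on either side. For compound 3 the expected value is 75%, between 55% and 90%.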

Compound 3, a percentage reported as inhibition, in the whole organism at one dose (the size of the read-out at that dose, not a potency): 54.6%
Compound 3: the middle estimate sits 20.4 percentage points above what was measured; measured number outside the range, below it.
By their numbers in this assay, from the lowest: compounds 3 and 1 (each within the scatter of the next); then compound 2.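

In this assay, the upward step seen with methyl on this aromatic nitrogen does not carry over to benzyl: the change from methyl to benzyl gives a number 25.4 percentage points lower from compound 2 to compound 3 (beyond the scatter), a step larger in size than the one that came with methyl. Set against the hydrogen on that nitrogen, benzyl gives a number 9 percentage points lower from compound 1 to compound 3 (within the scatter), so among these three compounds, filling this position does not in itself go with a higher number; methyl stands out, and benzyl goes against any general trend for substitution here. No data on hand account for the difference between methyl and benzyl at this position.

With only hydrogen, methyl and benzyl on this nitrogen, the series cannot separate the effect of chain length from that of the phenyl ring itself. From the compounds shown here alone, an ethyl or propyl chain, or a cyclohexylmethyl group, on the same nitrogen would address that question, and whether the standing of compound 2 holds at other doses or read-out times also remains open.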